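The compounds below may be only part of what the source reports. "The series", "measured", "known", "first", "only" and "open" are said of these compounds alone.

Measured in a functional assay on the whole organism for antagonist activity, with Mus musculus as the target, in the maximal electroshock model; a higher number here means that more compound is needed for the effect, a lower number that less compound is needed:

Compound 1 `Cn1c(-c2cccs2)nnc1[S+](C)[O-]`: > 200 mg/kg
Compound 2 `Cn1c(-c2cccs2)nnc1S(C)(=O)=O`: > 200 mg/kg
Compound 3 `Cn1c(-c2ccccc2)nnc1[S+](C)[O-]`: > 100 mg/kg

None of these three entries is a number, since each is a limit of the assay. On these data alone, compound 3 therefore stands at > 100 mg/kg, which is a limit, and its true position on the scale remains unknown.

Compound 4 `CC[S+]([O-])c1nnc(-c2ccccc2)n1C` differs from compound 3 by methyl in place of hydrogen on a saturated chain carbon bound to a sulfur. In words, this is methyl in place of hydrogen on a saturated chain carbon bound to a sulfur, or methyl to ethyl when the same difference is cut one bond further out.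

Little measured evidence bears on this change. For the measured compounds named here, the only step available is a step that the two limits leave unreadable from compound 1 to compound 2, and it concerns a different group on an aromatic carbon, so it offers neither a size nor a direction. No shift beyond the scatter can be predicted in this assay, and neither direction is favoured. Another report of only a limit is the likeliest outcome for compound 4.

The expected change is a step that the limit leaves unreadable from compound 3 to compound 4. For compound 4 the estimated value is 120 mg/kg, with an expected range from 50 mg/kg to 300 mg/kg.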

Compound 4, dose for half-maximal effect: > 200 mg/kg
Compound 4: no number, only a limit (the forecaster's own chance of this, stated with the estimate: 65%); at least 1.6-fold (0.22 log units) between middle value and limit.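

In this assay compound 3 gives > 100 mg/kg, which is a limit. Compound 4 gives > 200 mg/kg, which is also a limit. For the compounds shown here, no step can therefore be read between compound 3 and compound 4. The compounds shown leave open whether methyl in place of hydrogen on a saturated chain carbon bound to a sulfur shifts the dose for half-maximal effect at all, and in which direction.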